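Chloro for methyl on the anilino ring of compound 3

This account rests on a few compounds, and the source may have more. Where it says the series, first, only, none or still open, it means among the compounds named here.

Of the compounds shown here, three of one shared core have been tested in a functional assay, with a stated time of 150 min, tested at 10 ug/mL; on this read-out lower numbers stand for a weaker effect and higher numbers for a stronger effect at the one concentration tested. Compound 1 `COC(=O)c1c(Nc2ccc(C)cc2)sc(C(=O)c2ccc(OC)cc2)c1C` returned "not active" (no number reported), with no number reported. Compound 2 `COC(=O)c1c(Nc2ccc(OC)cc2)sc(C(=O)c2ccc(OC)cc2)c1C` gave 5.9% in this assay , a small read-out at the one concentration tested. Compound 3 `COc1ccc(C(=O)c2sc(Nc3ccc(C)cc3)c(C(=O)O)c2C)cc1` likewise came back as "not active" (no number reported) in this assay , again without a number. On what is shown, compound 3 therefore stands among the two entries that carry no single value, and the only numerical result in the set, that of compound 2, is itself small.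

Compound 4 `COc1ccc(C(=O)c2sc(Nc3ccc(Cl)cc3)c(C(=O)O)c2C)cc1` has not yet been measured. It differs from compound 3 in one place: chloro in place of methyl on an aromatic carbon. For the measured compounds named here, no measured pair in the set shares this change, so nothing here tells how large a step it brings. Given that compound 3 shows "not active" (no number reported) and compound 2 shows 5.9%, no step beyond the usual scatter in this assay is expected in either direction. Compound 4 is accordingly estimated to give about 6% in this assay , within a range from 0% to 20%, and it may well be reported without a number at all.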

Compound 4, a percentage reported as activity, at one concentration (the size of the read-out at that concentration, not a potency): "not active" (no number reported)
The entry for compound 4 holds no number; there is nothing to compare the estimate with.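

Compound 3 gives "not active" (no number reported) in this assay and compound 4 gives "not active" (no number reported), so no step can be read between them. Nothing shown offers an explanation for this result. The compounds shown leave open whether going from 4-methylphenyl to 4-chlorophenyl changes the read-out at all.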